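This account rests on a few compounds, and the source may have more. Where it says the series, first, only, none or still open, it means among the compounds named here.

In a functional assay on HCT-8 cells (Homo sapiens) for cytotoxicity, read by MTT assay, with a stated time of 4 days (a lower number here means a stronger inhibitor, a higher number a weaker inhibitor), two glycoside esters have been examined. Compound 1 `C[C@]1(O)C[C@@H](OC(=O)/C=C/c2ccccc2)[C@@H]2C=CO[C@@H](O[C@@H]3O[C@H](CO)[C@@H](O)[C@H](O)[C@H]3O)[C@@H]21` gives > 10000 nM, which is a limit of the assay and not a number. Compound 2 `CC(/C=C/[C@@]1(O)C(C)(C)CCC[C@@]1(C)O)=C\C(=O)O[C@@H]1C[C@](C)(O)[C@H]2[C@H](O[C@@H]3O[C@H](CO)[C@@H](O)[C@H](O)[C@H]3O)OC=C[C@H]21` gives > 10000 nM, again a limit rather than a number. Compound 2 therefore stands at the limit of > 10000 nM in this assay, at which 2 of the 2 values shown sit, and nothing in the numbers sets it apart from compound 1. The untested compound 3 `CC(/C=C/[C@@]1(O)C(C)(C)C[C@H](O)C[C@@]1(C)O)=C\C(=O)O[C@@H]1C[C@](C)(O)[C@H]2[C@H](O[C@@H]3O[C@H](CO)[C@@H](O)[C@H](O)[C@H]3O)OC=C[C@H]21` differs from compound 2 by hydroxy in place of hydrogen on a saturated ring carbon. The hydroxy enters on a saturated ring carbon of a six-membered non-aromatic ring of carbon only, so that the fragment reads 1,2-dihydroxy-2,6,6-trimethylcyclohexyl in compound 2 and 1,2,4-trihydroxy-2,6,6-trimethylcyclohexyl in compound 3. For the measured compounds named here, no step between measured compounds exists, so the outlook rests on the two limits and this change. With both known values at the limit of > 10000 nM in this assay, at which 2 of the 2 values shown sit, the expected step is a step that the limit leaves unreadable from compound 2 to compound 3, none beyond the scatter. Compound 3 is estimated at 15000 nM, with a range from 5000 nM to 50000 nM.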

Compound 3, half-maximal inhibitory concentration: > 10000 nM
Compound 3: a limit, no number (the forecaster's own chance of this, stated with the estimate: 85%); the middle value does not contradict the limit.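

Compound 3 gives > 10000 nM as a limit and not a number, so, with compound 2 also at a limit, no step can be read from compound 2 to compound 3. The compounds shown leave open whether the added hydroxy changes cytotoxicity at all, and what actual number any of the three would give.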